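The source may hold more compounds than are shown below. What is called first, only, known or untested is meant among the compounds shown, and "the series" means these compounds.

Compound 2 `O=c1cc(CC(O)COCc2ccccc2)[nH]c(=O)[nH]1` stands only at a limit in a functional assay on SW-620 cells (Homo sapiens) for antiproliferative activity, read by MTT assay, with a stated time of 72 h (a lower number here means a stronger inhibitor, a higher number a weaker inhibitor), where compound 2 gives > 100000 nM. Compound 1 `O=c1cc(CC(COCc2ccccc2)COCc2ccccc2)[nH]c(=O)[nH]1` likewise reaches only a limit in this assay, with compound 1 at > 100000 nM. The step that the two limits leave unreadable from compound 1 to compound 2 therefore cannot be read, as the limit of > 100000 nM in this assay, at which 2 of the 2 values shown sit, shows. Compound 3 `Cc1c(CC(O)COCc2ccccc2)[nH]c(=O)[nH]c1=O` differs from compound 2 by methyl in place of hydrogen on an aromatic carbon. Within the data shown here, no measured step bears on a methyl at this place, so no direction of this assay can be inferred beyond the scatter. Compound 3 is expected near 100000 nM, between 20000 nM and 300000 nM, an estimated step of a number no higher from compound 2 to compound 3 (the limit leaves the size open).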

Compound 3, half-maximal inhibitory concentration: > 100000 nM
Compound 3 ended at the assay's limit; the forecaster's own chance of this, stated with the estimate: 80%; the middle value lies on the limit itself.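

No new step can be read from compound 2 to compound 3, as both stand only at a limit: the limit of > 100000 nM in this assay, at which 3 of the 3 values shown sit.

The compounds shown leave open how the methyl or any other change on the shared core acts in this assay once a value falls inside the measurable range.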